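Nitrophenyl for Methylphenyl: Expected Cytotoxicity of Compound 4

The source may hold more compounds than are shown below. What is called first, only, known or untested is meant among the compounds shown, and "the series" means these compounds.

Compound 1 `CC(=O)OC[C@H]1O[C@H](OC[C@@H](CN=[N+]=[N-])OC(C)=O)C=C[C@@H]1OC(C)=O`: > 200 ug/mL
Compound 2 `CC(=O)OC[C@H]1O[C@H](OC[C@@H](Cn2cc(CN(c3nc(-c4ccc(C)cc4)no3)C3CCCCC3)nn2)OC(C)=O)C=C[C@@H]1OC(C)=O`: 36.8 ug/mL
Compound 3 `CC(=O)OC[C@H]1O[C@H](OC[C@H](Cn2cc(COc3ccc(-c4noc(C)n4)cc3)nn2)OC(C)=O)C=C[C@@H]1OC(C)=O`: 37.7 ug/mL

In an ADME assay on HepG2 cells (Homo sapiens) for cytotoxicity, read by MTT assay, with a stated time of 48 h (on this read-out lower numbers stand for higher toxicity in this test and higher numbers for lower toxicity in this test), compound 1 reaches only a limit, > 200 ug/mL, which is the limit of > 200 ug/mL in this assay, at which 1 of the 3 values shown sits. Compound 2 gives 36.8 ug/mL, the lowest of the two numbers. Compound 3 gives 37.7 ug/mL, within the scatter of compound 2, so the two are not separated. Compound 4 `CC(=O)OC[C@H]1O[C@H](OC[C@@H](Cn2cc(CN(c3nc(-c4cccc([N+](=O)[O-])c4)no3)C3CCCCC3)nn2)OC(C)=O)C=C[C@@H]1OC(C)=O` differs from compound 2 in one place: 3-nitrophenyl in place of 4-methylphenyl on an aromatic carbon. Going by the values given here, no measured pair in this set shows such a change, so no step can be read from the data. Compound 4 is expected to move by a 1.1-fold lower number from compound 2 to compound 4 (0.02 log units; within the scatter) in this assay, a step not beyond the scatter. Compound 4 is therefore estimated at 35 ug/mL, with a range from 15 ug/mL to 80 ug/mL.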

Compound 4, half-maximal cytotoxic concentration: > 200 ug/mL
Compound 4 was reported as a limit; the forecaster's own chance of this, stated with the estimate: 5%; middle value at least 5.7-fold (0.75 log units) away from the limit.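

In this assay, this place on the five-membered aromatic ring, between two ring nitrogen atoms, proves sensitive to the aryl group: 3-nitrophenyl in place of 4-methylphenyl gives an at least 5.4-fold higher number from compound 2 to compound 4 (0.73 log units; beyond the scatter). Going by these compounds alone, the earlier compounds offered no single change at this position, so this is the first sign that it matters. The reading for compound 4 is a limit: the limit of > 200 ug/mL in this assay, at which 2 of the 4 values shown sit.

The compounds shown leave open whether the step follows the nitro group or its place on the phenyl ring; a 4-nitrophenyl or a 3-methylphenyl here would separate the two.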